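Sulfanyl in place of propylamino on the shared core

The source may hold more compounds than are shown below. What is called first, only, known or untested is meant among the compounds shown, and "the series" means these compounds.

Compound 3 `CCCNc1nc2cc(Cl)c(Cl)cc2n1[C@@H]1O[C@H](CO)[C@@H](O)[C@H]1O` sits at the limit of a functional assay on KB cells (Homo sapiens) for inhibition; a lower number here means a stronger inhibitor, a higher number a weaker inhibitor: in this assay compound 3 gives > 100000 nM, a limit and not a number. Compound 1 `CNc1nc2cc(Cl)c(Cl)cc2n1[C@@H]1O[C@@H](CO)[C@@H](O)[C@H]1O` gives > 100000 nM, also a limit. Compound 2 `OC[C@@H]1O[C@@H](n2c(SCc3ccccc3)nc3cc(Cl)c(Cl)cc32)[C@H](O)[C@@H]1O` gives 40000 nM. The change to compound 4 `OC[C@H]1O[C@@H](n2c(S)nc3cc(Cl)c(Cl)cc32)[C@H](O)[C@@H]1O` is sulfanyl in place of propylamino on an aromatic carbon. Within the data shown here, the only measured step at this position, an at least 2.5-fold lower number from compound 1 to compound 2 (0.39 log units; beyond the scatter), likewise swaps an alkylamino group for a sulfur-bearing one, but there benzylsulfanyl entered, here the bare sulfanyl. That step was modest and began at the limit (the limit of > 100000 nM in this assay, at which 2 of the 3 values shown sit), so at most a small move toward a measurable number is expected. For compound 4 in this assay the estimate is 100000 nM, with a range from 30000 nM to 300000 nM. This corresponds to an expected a number no higher from compound 3 to compound 4 (the limit leaves the size open).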

Compound 4, half-maximal inhibitory concentration: > 100000 nM
Compound 4: only a limit was reported (the forecaster's own chance of this, stated with the estimate: 60%); the middle value sits exactly at the limit.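

Compound 3 and compound 4 both stand only as limits in this assay, and no step between them can be read: the limit of > 100000 nM in this assay, at which 3 of the 4 values shown sit.

The compounds shown leave open whether sulfanyl in place of propylamino changes inhibition on the shared core at all.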